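From 4-chlorophenyl to 3,4-dimethylphenyl: working notes

The compounds below may be only part of what the source reports. "The series", "measured", "known", "first", "only" and "open" are said of these compounds alone.

Measured in a functional assay on A549 cells (Homo sapiens) for inhibition, read by CCK-8 assay, with a stated time of 48 h (a higher number here means a weaker inhibitor, a lower number a stronger inhibitor), as follows:
- compound 1 `COc1cc(-c2ccnc3cc(-c4ccc(F)cc4)nn23)cc(OC)c1OC` gives 3800 nM
- compound 2 `COc1cc(-c2ccnc3cc(-c4ccc(Cl)cc4)nn23)cc(OC)c1OC` gives 3070 nM
- compound 3 `Cn1ccc2cc(-c3cc4nccc(-c5ccc(F)cc5)n4n3)ccc21` gives 3520 nM

Compound 2 at 3070 nM sits within the scatter of compound 1 and of compound 3 and no order can be read among the three. The next compound to consider is compound 4 `COc1cc(-c2ccnc3cc(-c4ccc(C)c(C)c4)nn23)cc(OC)c1OC` which is still unmeasured. The change from compound 2 is 3,4-dimethylphenyl in place of 4-chlorophenyl on an aromatic carbon and it replaces the whole aryl group that carries the halogen.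

Going by the values given here, one measured step bears on this change. The step of a 1.2-fold lower number from compound 1 to compound 2 (0.09 log units; within the scatter) is chloro in place of fluoro on an aromatic carbon and it stays within the scatter. Among the compounds with values here, it exchanges one halogen for another, so it says little about the methyl groups, and no measured compound carries them. Compound 3 offers no comparison that differs in one place only.

In this assay, as far as these compounds go, no step beyond the scatter is therefore expected, and the direction stays open. The expected step is a 1.0-fold lower number from compound 2 to compound 4 (0.01 log units; within the scatter) as an estimate only. For compound 4 the estimated value is 3000 nM with an expected range of 1200 nM to 7500 nM as the working figure, kept wide for the untested group.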

Compound 4, half-maximal inhibitory concentration: 272 nM
Beside the measured number, compound 4's estimate is 11-fold (1.04 log units) above it, outside the stated range (below it).
By their numbers in this assay, from the lowest: compound 4; then compounds 2, 3 and 1 (each within the scatter of the next).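

In this assay, the aryl group on this aromatic carbon of the five-membered ring turns out to be a position that can move the number a long way: the result is an 11-fold lower number from compound 2 to compound 4 (1.05 log units; beyond the scatter), and against the fluoro analogue it is a 14-fold lower number from compound 1 to compound 4 (1.15 log units; beyond the scatter). The halogen exchange alone gave no sign of this, with a 1.2-fold lower number from compound 1 to compound 2 (0.09 log units; within the scatter). Among these compounds, then, the two halogen-bearing aryl groups cannot be told apart, and the large step appears only when 3,4-dimethylphenyl takes the place of either one on the shared core.

Still open, as far as these compounds go, is whether one methyl group alone would carry the step or both are needed, whether a longer chain such as ethyl, a methoxy group or an amine on the same phenyl ring would go further, and whether 3,4-dimethylphenyl would give a comparable step on the core of compound 3. No measurement shown offers any explanation for the size of this step, so it stands as an observation in this one cell assay only.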